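The source may report more compounds than this note shows. Statements on the series, on what has been measured and on what is new or still open speak of the compounds shown alone.

Measured compounds:
Compound 1 `Cc1ccn2c(NC3CCCC3)c(-c3ccc(N(C)C)cc3)nc2c1`: in an ADME assay on THP-1 cells (Homo sapiens) for cytotoxicity (on this read-out higher numbers stand for lower toxicity in this test and lower numbers for higher toxicity in this test), compound 1 gives > 50000 nM, which is a limit of the assay.
Compound 2 `CN(C)c1ccc(-c2nc3ccccn3c2NC2CCCC2)cc1`: in this assay compound 2 gives > 50000 nM, again a limit of the assay.

Among the measured compounds shown here, compound 1 therefore stands only at a limit in this assay; no number is known for it, and the one further value shown is a limit too. For the measured compounds named here, the single measured step, a step that the two limits leave unreadable from compound 1 to compound 2, swaps hydrogen for methyl on an aromatic carbon, and its size cannot be read because both of its ends sit at the limit of > 50000 nM in this assay, at which 2 of the 2 values shown sit. Compound 3 `COc1ccc(-c2nc3cc(C)ccn3c2NC2CCCC2)cc1` is not yet measured. It differs from compound 1 by methoxy in place of dimethylamino on an aromatic carbon. Going by the values given here, no measured step touches this group, and the one step that exists is unreadable, so nothing points to a change beyond the scatter in this assay. Compound 3 is expected to show a step of a number no higher from compound 1 to compound 3 (the limit leaves the size open) and to remain at the limit. Compound 3 is estimated at 50000 nM, in the range 20000 nM to 120000 nM.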

Compound 3, half-maximal cytotoxic concentration: > 50000 nM
Compound 3: no number, only a limit (the forecaster's own chance of this, stated with the estimate: 75%); the middle value lies on the limit itself.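

Compound 1 and compound 3 both stand at a limit of the assay rather than at a number, so the swap of dimethylamino for methoxy between them cannot be read: the limit of > 50000 nM in this assay, at which 3 of the 3 values shown sit. The compounds shown leave open what concentration would give a half-maximal cytotoxic effect for any of them in this assay.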